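Trifluoromethyl in place of methoxy on an aromatic carbon

The source may report more compounds than this note shows. Statements on the series, on what has been measured and on what is new or still open speak of the compounds shown alone.

Three compounds have numbers in a functional assay on MCF7 cells (Homo sapiens) for antiproliferative activity, read by MTT assay, with a stated time of 72 h; a lower number here means a stronger inhibitor, a higher number a weaker inhibitor. Compound 1 (`O=S1(=O)C=Cc2ccc(Nc3ccc(F)c(F)c3)cc21`) gives 2610 nM, compound 2 (`COc1ccc(Nc2cccc3c2S(=O)(=O)C=C3)cc1`) gives 940 nM and compound 3 (`COc1ccccc1Nc1cccc2c1S(=O)(=O)C=C2`) gives 5100 nM. Compound 3 thus stands at the high end of these numbers, level within the scatter with compound 1 and beyond the scatter above compound 2. Compound 4 (`O=S1(=O)C=Cc2cccc(Nc3ccccc3C(F)(F)F)c21`) carries trifluoromethyl in place of methoxy on an aromatic carbon, ortho to a large group (trifluoromethyl in place of methoxy on an aromatic carbon). For the measured compounds named here, no measured pair shows this change, so the expectation starts from compound 3 at 5100 nM, and no step beyond the scatter is expected in this assay. The estimate is a 1.3-fold lower number from compound 3 to compound 4 (0.11 log units; within the scatter). Compound 4 is expected at 4000 nM, with an estimated range of 1500 nM to 11000 nM.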

Compound 4, half-maximal inhibitory concentration: 8100 nM
For compound 4 the middle estimate is 2.0-fold (0.31 log units) below the measured one; low and high end bracket the measured number.
By their numbers in this assay, from the lowest: compound 2; then compounds 1, 3 and 4 (each within the scatter of the next, the first and the last beyond it).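

In this assay, for the compounds shown here, trifluoromethyl in place of methoxy on this aromatic carbon, ortho to a large group, gives the first direct step at this position, a 1.6-fold higher number from compound 3 to compound 4 (0.20 log units; within the scatter), so the read-out does not separate the two groups here. The hydrogen-bond acceptor counted for methoxy can thus be lost at this place with no step beyond the scatter. Nothing at hand bears on why the two groups read alike.

On these data alone, what a hydroxyl, an amine or a carboxylic acid would give on this carbon stays open. So does whether the same change would give a similar step at another place on the ring.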